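Changing the Aryl Group on Compound 1

The source may report more compounds than this note shows. Statements on the series, on what has been measured and on what is new or still open speak of the compounds shown alone.

Among the measured compounds shown here, in a functional assay on MCF7 cells (Homo sapiens) for inhibition, read by fluorescence, with a stated time of 72 h (on this read-out higher numbers stand for weaker inhibition of growth and lower numbers for stronger inhibition of growth), compound 1 `COc1ccc(Nc2nc(N[C@H]3CC[C@H](N)CC3)nc3c2ncn3CCC(C)C)c(OC)c1` gives 6300 nM, the higher of the two numbers so far, while compound 2 `CCCCn1cnc2c(Nc3ccc(Cl)cc3)nc(N[C@H]3CC[C@H](N)CC3)nc21` gives 2100 nM. Compound 3 `CC(C)CCn1cnc2c(Nc3cccc(O)c3)nc(N[C@H]3CC[C@H](N)CC3)nc21` has not yet been measured. It carries 3-hydroxyphenyl in place of 2,4-dimethoxyphenyl on a nitrogen on an aromatic ring. Compound 2 at 2100 nM offers only a loose guide, as it differs from compound 1 in more than one place. A modest move towards stronger inhibition is expected in this assay, with an estimated 2.5-fold lower number from compound 1 to compound 3 (0.40 log units; beyond the scatter). For compound 3 the expected value is 2500 nM, within a range of 700 nM to 8000 nM.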

Compound 3, concentration for 50% growth inhibition: 12600 nM
For compound 3 the middle estimate is 5.0-fold (0.70 log units) below the measured one; measured number above the stated range.
By their numbers in this assay, from the lowest: compound 2; then compounds 1 and 3 (each within the scatter of the next).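

Among the compounds shown here, this is the first comparison in which only the group on the nitrogen changes, and in this assay it gives a 2.0-fold higher number from compound 1 to compound 3 (0.30 log units; within the scatter). Replacing 2,4-dimethoxyphenyl with 3-hydroxyphenyl therefore causes no change that can be told from scatter, even though the two groups differ in size and in their counts of hydrogen-bond donors and acceptors. Nothing available explains this result.

As far as these compounds go, it remains open whether an aminophenyl or a carboxyphenyl group at this nitrogen would move the number beyond the scatter. The effect of such a group on growth inhibition cannot be inferred from these two aryl groups.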